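This account rests on a few compounds, and the source may have more. Where it says the series, first, only, none or still open, it means among the compounds named here.

Measured so far in a functional assay on CEM-DNR-bulk cells (Homo sapiens), read by MTT assay, with a stated time of 72 h; a lower number here means a stronger inhibitor, a higher number a weaker inhibitor:
Compound 1 `C#Cc1cn([C@@H]2O[C@H](CO)[C@@H](O)[C@H]2O)c2ncnc(OC)c12` gives 3490 nM.
Compound 2 `C#Cc1cn([C@@H]2O[C@H](CO)[C@@H](O)[C@H]2O)c2ncnc(N(C)C)c12` gives 240 nM.
Compound 3 `C#Cc1cn([C@@H]2O[C@H](CO)[C@@H](O)[C@H]2O)c2ncnc(C)c12` gives 160 nM.

Among these three numbers compound 2 holds the second highest; its nearest neighbour is compound 3, reached by a 1.5-fold lower number from compound 2 to compound 3 (0.18 log units; within the scatter), while the furthest is compound 1, from which a 15-fold lower number from compound 1 to compound 2 (1.16 log units; beyond the scatter) leads to compound 2. Compound 4 `CN(C)c1ncnc2c1c(-c1ccoc1)cn2[C@@H]1O[C@H](CO)[C@@H](O)[C@H]1O` keeps the whole of compound 2 except for one change, (furan-3-yl in place of ethynyl on an aromatic carbon). For the measured compounds named here, none of the measured steps touches this position: a 15-fold lower number from compound 1 to compound 2 (1.16 log units; beyond the scatter), a 22-fold lower number from compound 1 to compound 3 (1.34 log units; beyond the scatter) and a 1.5-fold lower number from compound 2 to compound 3 (0.18 log units; within the scatter) all swap the group on the other aromatic carbon, so they tell how much that side matters but nothing about the ethynyl. Going by the values given here, with no measured step bearing on the change, the expected direction is open, and the estimate for compound 4 is set close to compound 2 with a wide range, a 1.5-fold higher number from compound 2 to compound 4 (0.16 log units; within the scatter). Compound 4 is thus expected to give about 350 nM in this assay, between 60 nM and 2000 nM.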

Compound 4, half-maximal inhibitory concentration: > 20000 nM
Compound 4 ended at the assay's limit; the forecaster's own chance of this, stated with the estimate: 5%; at least 57-fold (1.75 log units) between middle value and limit.
By their numbers in this assay, from the lowest: compounds 3 and 2 (each within the scatter of the next); then compound 1. At a limit, above all of these: compound 4.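

The earlier compounds shown here changed only the other aromatic carbon, whereas compound 4 tests the carbon that carries the ethynyl, and there the change has a large effect. In this assay, furan-3-yl in place of ethynyl gives an at least 83-fold higher number from compound 2 to compound 4 (1.92 log units; beyond the scatter), so this position does not accept every group, and the dimethylamino group of compound 2 does not keep the activity on its own. The reading for compound 4 is a limit of the assay, not a number: the limit of > 20000 nM in this assay, at which 1 of the 4 values shown sits.

The compounds shown cannot separate the loss of the triple bond from the arrival of a ring or of its oxygen. As far as these compounds go, it remains open how a vinyl group, a nitrile or a phenyl ring would fare on this carbon, and whether furan-3-yl behaves the same way with methyl on the other aromatic carbon.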